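Replacing Vinylsulfonyl with a Fluorophenylcarbamoyl Group

This account rests on a few compounds, and the source may have more. Where it says the series, first, only, none or still open, it means among the compounds named here.

The measured compounds, with their results in a functional assay on MDA-MB-231 cells (Homo sapiens) for antiproliferative activity, read by MTT assay, with a stated time of 48 h; on this read-out higher numbers stand for weaker inhibition and lower numbers for stronger inhibition:
Compound 1 `C=CS(=O)(=O)N1CCN(c2ncnc3sc(-c4ccccc4)cc23)CC1` gives 54200 nM.
Compound 2 `C=CS(=O)(=O)N1CCN(c2ncnc3sc(-c4ccc(N5CCN(C)CC5)cc4)cc23)CC1` gives 7550 nM.
Compound 3 `C=CS(=O)(=O)N1CCN(c2ncnc3sc(-c4ccc(N5CCN(C)CC5)cc4)cc23)[C@@H](C)C1` gives 6180 nM.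

Compound 2 stands second highest of these three numbers. Its nearest neighbour is compound 3, reached by a 1.2-fold lower number from compound 2 to compound 3 (0.09 log units; within the scatter), a change within the scatter. Its furthest is compound 1: a 7.2-fold lower number from compound 1 to compound 2 (0.86 log units; beyond the scatter).

Compound 4 `CN1CCN(c2ccc(-c3cc4c(N5CCN(C(=O)Nc6cccc(F)c6)CC5)ncnc4s3)cc2)CC1` differs from compound 2 in one place: (3-fluorophenyl)carbamoyl in place of vinylsulfonyl on an amine nitrogen in a ring. Neither measured step touches this part of the molecule. The step from compound 1 to compound 2 altered a substituent on an aromatic carbon, and the step from compound 2 to compound 3 added a methyl to a saturated ring carbon; both leave the amine nitrogen that now changes untouched. The data therefore give no direct guide to the size or direction of the step. Without such a guide, the expectation for compound 4 is a result close to that of compound 2, with wide uncertainty: an estimated 5000 nM, between 800 nM and 30000 nM, which would mean an expected step of a 1.5-fold lower number from compound 2 to compound 4 (0.18 log units; within the scatter).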

Compound 4, half-maximal inhibitory concentration: 13200 nM
Beside the measured number, compound 4's estimate is 2.6-fold (0.42 log units) below it; low and high end bracket the measured number.
By their numbers in this assay, from the lowest: compounds 3, 2 and 4 (each within the scatter of the next, the first and the last beyond it); then compound 1.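

In this assay, putting (3-fluorophenyl)carbamoyl in place of vinylsulfonyl on the amine nitrogen in a ring gives a 1.7-fold higher number from compound 2 to compound 4 (0.24 log units; within the scatter) and so no change that can be told from repeat scatter. This position therefore takes a group with more heavy atoms, an added aromatic ring and a hydrogen-bond donor without a step beyond the scatter, and compound 4 shows that vinylsulfonyl is not needed for a result of this size in this pair. No measurement at hand gives a reason why the two groups read alike.

Still open, from the compounds shown here alone, is whether the fluorine matters, which a plain phenylcarbamoyl on the same nitrogen would test. Going by these compounds alone, also open is how a small acetyl group or a longer carbon chain there would read, since only two groups at this position can be compared.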